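The compounds below may be only part of what the source reports. "The series", "measured", "known", "first", "only" and "open" are said of these compounds alone.

Going by the values given here, in a functional assay on KYSE-450 cells (Homo sapiens) for inhibition, read by MTT assay, with a stated time of 48 h (on this read-out lower numbers stand for stronger inhibition and higher numbers for weaker inhibition), compound 1 (`CCCCC(=O)N(Cc1ccc(OC)c(O)c1)c1cc(OC)c(OC)c(OC)c1`) gives 300 nM and compound 2 (`COc1ccc(CN(C(=O)C=C(C)C)c2cc(OC)c(OC)c(OC)c2)cc1O`) gives 280 nM in the same read-out, so compound 2 stands level with its only measured neighbour, inside the scatter. Compound 3 (`C#CC(=O)N(Cc1ccc(OC)c(O)c1)c1cc(OC)c(OC)c(OC)c1`) keeps the shared core and changes only the group on the carbonyl carbon, with ethynyl in place of 2-methylprop-1-en-1-yl (ethynyl in place of 2-methylprop-1-en-1-yl on a carbonyl carbon). Among the compounds with values here, one measured step bears on this place, a 1.1-fold lower number from compound 1 to compound 2 (0.03 log units; within the scatter) (2-methylprop-1-en-1-yl in place of butyl on the same carbonyl carbon). Within the data shown here, that single step stayed inside the scatter, so no step beyond the scatter is expected in this assay here, in either direction, although no measured compound carries a triple bond. The expected change is small (a 1.3-fold higher number from compound 2 to compound 3 (0.10 log units; within the scatter)). Compound 3 is estimated at 350 nM as a middle value, with an expected range from 100 nM to 1200 nM for repeat measurements.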

Compound 3, half-maximal inhibitory concentration: 570 nM
For compound 3 the middle estimate is 1.6-fold (0.21 log units) below the measured one, within the range that was stated.
By their numbers in this assay, from the lowest: compounds 2, 1 and 3 (each within the scatter of the next, the first and the last beyond it).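

In this assay, going by these compounds alone, the change gives a 2.0-fold higher number from compound 2 to compound 3 (0.31 log units; beyond the scatter) and so is the first step on this carbonyl carbon to pass beyond the scatter, though only a modest one. Set against butyl, the same ethynyl gives a 1.9-fold higher number from compound 1 to compound 3 (0.28 log units; within the scatter) and stays within the scatter, so the shift is resolved only against 2-methylprop-1-en-1-yl and does not amount to a general penalty for the triple bond. Nothing available here accounts for the shift.

Going by these compounds, whether a phenyl ring, an amine or a longer chain on this carbonyl carbon would move the number further remains open. Also open, on these data alone, is whether the small difference between ethynyl and 2-methylprop-1-en-1-yl would hold in cells other than the line tested here.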